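The compounds below may be only part of what the source reports. "The series", "measured", "known", "first", "only" and "open" are said of these compounds alone.

Compound 1 `OC[C@H]1O[C@@H](n2cc(F)c3c(-c4ccco4)ncnc32)[C@H](O)[C@@H]1O` gives 29000 nM in an ADME assay on MRC5 cells (Homo sapiens) for cytotoxicity, read by MTT assay, with a stated time of 72 h; on this read-out lower numbers stand for higher toxicity in this test and higher numbers for lower toxicity in this test.
Compound 2 `OC[C@H]1O[C@@H](n2cc(F)c3c(-c4cccs4)ncnc32)[C@H](O)[C@@H]1O` gives 47200 nM in this assay.

Compound 1 holds the lowest of the two numbers, with compound 2 nearest. Among the measured compounds shown here, the only measured step, a 1.6-fold higher number from compound 1 to compound 2 (0.21 log units; within the scatter), swaps one five-membered ring for another on the shared core and stays within the scatter. Compound 3 `OC[C@H]1O[C@@H](n2cc(F)c3c(-c4nccs4)ncnc32)[C@H](O)[C@@H]1O` makes a related change: 1,3-thiazol-2-yl in place of furan-2-yl on an aromatic carbon. That one comparable step bears directly on it and was small. Compound 3 is therefore expected to move little in this assay, the estimated step being a 1.4-fold higher number from compound 1 to compound 3 (0.14 log units; within the scatter). Compound 3 is estimated at 40000 nM, with a range from 18000 nM to 90000 nM.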

Compound 3, half-maximal cytotoxic concentration: > 50000 nM
Compound 3: a limit, no number (the forecaster's own chance of this, stated with the estimate: 15%); middle value at least 1.2-fold (0.09 log units) away from the limit.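

Compound 3 gives no number in this assay, only a limit of the assay: the limit of > 50000 nM in this assay, at which 1 of the 3 values shown sits. The steps, an at least 1.7-fold higher number from compound 1 to compound 3 (0.23 log units; that floor lies within the scatter) and an at least 1.0-fold higher number from compound 2 to compound 3 (0.02 log units; that floor lies within the scatter), are floors, and both lie within the scatter. They show that a five-membered aromatic ring with 2 hetero atoms on this aromatic carbon brings no fall in the number, but not how large any rise is. Still open, from the compounds shown here alone, is how far past its limit compound 3 lies, and how an amine or a carboxylic acid in place of the five-membered ring would read in this assay.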